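The source may hold more compounds than are shown below. What is called first, only, known or untested is meant among the compounds shown, and "the series" means these compounds.

Measured so far:
Compound 1, `O=C1/C(=C/c2ccccc2)NS(=O)(=O)c2ccccc21`, gives 1780 nM in an assay for inhibition of Intestinal-type alkaline phosphatase (Homo sapiens), read by spectrophotometry, with stated times of 10 min and 20 min; a higher number here means a weaker inhibitor, a lower number a stronger inhibitor.
Compound 2, `O=C1/C(=C/c2ccc(F)cc2)NS(=O)(=O)c2ccccc21`, gives 3060 nM in this assay.

Compound 2 gives the highest of the two numbers shown, and its only neighbour is compound 1; the step of a 1.7-fold higher number from compound 1 to compound 2 (0.24 log units; within the scatter) stays within the scatter, so the two compounds cannot be ranked against each other. Compound 3, `O=C1/C(=C/c2cccc(O)c2)NS(=O)(=O)c2ccccc21`, has not yet been measured. It differs from compound 2 in one place: 3-hydroxyphenyl in place of 4-fluorophenyl on a double-bonded chain carbon bound to a double-bonded ring carbon. Within the data shown here, the only measured step here, a 1.7-fold higher number from compound 1 to compound 2 (0.24 log units; within the scatter), swaps hydrogen for fluorine on the same aromatic ring and stays within the scatter. Among the measured compounds shown here, it bears on the new step only loosely, since the group that enters carries a hydroxyl at a different position on that ring, and no measured pair shows what a hydroxyl does on this shared core. With nothing beyond a small, within-scatter step on record, compound 3 is expected to give a number close to that of compound 2, with no step beyond the scatter in either direction. For compound 3 the estimated value in this assay is 2200 nM, with a likely range from 700 nM to 7000 nM. This estimate means a step of a 1.4-fold lower number from compound 2 to compound 3 (0.14 log units; within the scatter), which is expected to fall within the scatter.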

Compound 3, half-maximal inhibitory concentration: 1210 nM
Compound 3: the middle estimate sits 1.8-fold (0.26 log units) above what was measured; the measured number falls inside the stated range.
By their numbers in this assay, from the lowest: compounds 3, 1 and 2 (each within the scatter of the next, the first and the last beyond it).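

In this assay, among these compounds, putting 3-hydroxyphenyl in place of 4-fluorophenyl on the double-bonded chain carbon bound to a double-bonded ring carbon gives a 2.5-fold lower number from compound 2 to compound 3 (0.40 log units; beyond the scatter), the first step in this small set that lies beyond the scatter, though only modestly. The comparison with the unsubstituted phenyl group is less clear: hydroxy in place of hydrogen gives a 1.5-fold lower number from compound 1 to compound 3 (0.17 log units; within the scatter), which stays within the scatter, so the hydroxyl cannot be said to improve on the plain ring, and the gap between the other two compounds cannot be credited to the hydroxyl alone, since that step removes a fluorine and adds a hydroxyl at a different ring position. Nothing available here accounts for the size of this step.

These compounds do not separate the identity of a ring substituent from its position, which would take a hydroxyl and a fluorine each tested at the other's ring position. As far as these compounds go, it also remains open whether a methoxy group, an amine or a carboxylic acid on this ring would move the number further than the small steps seen so far.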